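The source may report more compounds than this note shows. Statements on the series, on what has been measured and on what is new or still open speak of the compounds shown alone.

Compound 1 `COCCOC(=O)c1cc(N)c(Nc2ccc(C#N)cc2)cc1Oc1c(C)cc(/C=C/C#N)cc1C`: 0.77 ug/mL
Compound 2 `Cc1cc(/C=C/C#N)cc(C)c1Oc1cc(Nc2ccc(C#N)cc2)c(N)cc1C(=O)NN`: 2.4 ug/mL
Compound 3 `Cc1cc(/C=C/C#N)cc(C)c1Oc1cc(Nc2ccc(C#N)cc2)c(N)cc1C(N)=O`: 0.63 ug/mL

In a physicochemical assay for solubility, read by HPLC, in phosphate buffer, with a stated time of 4 h, at pH 7.4 (on this read-out lower numbers stand for lower solubility and higher numbers for higher solubility), compound 2 stands highest of the three measured compounds, with both of its steps to the others beyond the scatter: the rise a 3.1-fold higher number from compound 1 to compound 2 (0.49 log units; beyond the scatter) and the fall a 3.8-fold lower number from compound 2 to compound 3 (0.58 log units; beyond the scatter). The step between compound 1 and compound 3, a 1.2-fold lower number from compound 1 to compound 3 (0.09 log units; within the scatter), lies within the scatter, so the two esters and amides with a plain carbonyl substituent sit together below the hydrazide.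

Compound 4 `Cc1cc(/C=C/C#N)cc(C)c1Oc1cc(Nc2ccc(C#N)cc2)c(N)cc1C(=O)OCCC#N` differs from compound 2 by 2-cyanoethoxy in place of aminoamino on a carbonyl carbon. The step that bears on it most directly is the one from the 2-methoxyethyl ester to the hydrazide, a 3.1-fold higher number from compound 1 to compound 2 (0.49 log units; beyond the scatter), together with the step to the primary amide, a 3.8-fold lower number from compound 2 to compound 3 (0.58 log units; beyond the scatter): in both cases removing the aminoamino group lowers the number by a modest amount. Compound 4 replaces the same group with another ester, so a modest drop in this assay is expected, of about a 3.0-fold lower number from compound 2 to compound 4 (0.48 log units; beyond the scatter). Compound 4 is therefore estimated at 0.8 ug/mL, with a likely range from 0.3 ug/mL to 2 ug/mL.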

Compound 4, solubility: 0.36 ug/mL
Compound 4: middle estimate off by 2.2-fold (0.35 log units), on the high side; measured number inside the range.
By their numbers in this assay, from the lowest: compounds 4, 3 and 1 (each within the scatter of the next, the first and the last beyond it); then compound 2.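

In this assay, the carbonyl substituent now has a third group falling clearly short of the hydrazide, with 2-cyanoethoxy in place of aminoamino giving a 6.7-fold lower number from compound 2 to compound 4 (0.82 log units; beyond the scatter). The ester chain itself also matters at this position: cyano in place of methoxy on the saturated chain gives a 2.1-fold lower number from compound 1 to compound 4 (0.33 log units; beyond the scatter), a step beyond the scatter, whereas the comparison with the primary amide, a 1.8-fold lower number from compound 3 to compound 4 (0.24 log units; within the scatter), stays within it. Nothing measured here accounts for these differences.

As far as these compounds go, it remains open whether a carboxylic acid or an aminoethyl ester on this carbonyl carbon would stand with the hydrazide or with the other three compounds. From the compounds shown here alone, it is also open whether a longer chain carrying the nitrile would extend the step seen between the two esters.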